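Stereochemistry and cytotoxicity in a small thioester series

The source may hold more compounds than are shown below. What is called first, only, known or untested is meant among the compounds shown, and "the series" means these compounds.

Compound 1 `O=C(S[C@@]12CC[C@H](O)[C@@H]1C(=O)NC2=O)c1ccc(O)cc1`: 1020000 nM
Compound 2 `O=C(SC12CCC(O)C1C(=O)NC2=O)c1ccc(O)cc1`: 434000 nM

Among the compounds with values here, in an ADME assay on RAW264.7 cells (Mus musculus) for cytotoxicity, read by MTT assay, with a stated time of 24 h (a lower number here means a stronger inhibitor, a higher number a weaker inhibitor), compound 2 gives the lower of the two numbers measured so far, with compound 1 a step away: a 2.4-fold lower number from compound 1 to compound 2 (0.37 log units; beyond the scatter). Compound 3 `O=C(S[C@@]12CC[C@@H](O)[C@@H]1C(=O)NC2=O)c1ccc(O)cc1` differs from compound 2 by the two compounds have the same atoms and bonds; at least one stereo element is drawn with a configuration in one of them and without one in the other: 3 of 3 stereo elements differ; a stereocentre at a saturated ring carbon is drawn without a configuration in compound 2 and S in compound 3; a stereocentre at a saturated ring carbon is drawn without a configuration in compound 2 and R in compound 3; a stereocentre at a saturated ring carbon is drawn without a configuration in compound 2 and R in compound 3. Within the data shown here, the only measured step that bears on this change is a 2.4-fold lower number from compound 1 to compound 2 (0.37 log units; beyond the scatter), which rests on the fact that one of compounds 1 and 2 is drawn with a defined configuration and the other without, at the place where they differ and was modest. A drawn configuration is again being introduced, so a modest rise in this assay is expected. Compound 3 is therefore estimated at 650000 nM, in a range from 250000 nM to 1600000 nM, a step of a 1.5-fold higher number from compound 2 to compound 3 (0.18 log units; within the scatter).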

Compound 3, half-maximal inhibitory concentration: 2910000 nM
Beside the measured number, compound 3's estimate is 4.5-fold (0.65 log units) below it, and the stated range ends below it.
By their numbers in this assay, from the lowest: compound 2; then compound 1; then compound 3.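

In this assay, changing one stereocentre at a saturated ring carbon from S to R gives a 2.9-fold higher number from compound 1 to compound 3 (0.46 log units; beyond the scatter), so configuration at this single place alone moves the number beyond the scatter. Drawing all three stereocentres gives a 6.7-fold higher number from compound 2 to compound 3 (0.83 log units; beyond the scatter), a larger step than the earlier one between compound 1 and compound 2. Both compounds with fully drawn configurations therefore give higher numbers than compound 2, but not equally high.

Still open, going by these compounds, is which configurations the sample of compound 2 contains. On these data alone, it is also open whether an amine on the shared core would shift the number as these stereocentres do.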